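Alpha-1D series: ortho-substituted aryl piperazines with pyridine carboxamides

This account rests on a few compounds, and the source may have more. Where it says the series, first, only, none or still open, it means among the compounds named here.

Measured so far:
compound 1 `COc1ccccc1N1CCN(CCCNc2ncccc2C(=O)NC(C)(C)C)CC1`, 10 nM in a functional assay on aorta for antagonist activity at Alpha-1D adrenergic receptor (Rattus norvegicus); a lower number here means tighter binding, a higher number weaker binding
compound 2 `COc1ccccc1N1CCN(CCCNc2ncccc2C(=O)C2CC2)CC1`, 2 nM
compound 3 `CN(C)C(=O)c1cccnc1NCCCN1CCN(c2ccccc2OC(F)(F)F)CC1`, 100 nM

Compound 3 gives the highest of the three numbers in this assay. Against compound 1 the gap is a 5.0-fold lower number from compound 1 to compound 2 (0.70 log units; beyond the scatter) only for the carbonyl change; compound 3 differs from compound 1 in two places, so its values against compounds 1 and 2 show a wide gap without a single assignable cause.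

Compound 4 `CC(C)c1ccccc1N1CCN(CCCNc2ncccc2C(=O)N(C)C)CC1` keeps the dimethylamide of compound 3 and changes the aryl group: isopropyl in place of trifluoromethoxy on an aromatic carbon. Among the compounds with values here, no measured step touches this position, so no direction is supported. The number for compound 4 is expected at 70 nM (range 15 nM to 300 nM), a step of a 1.4-fold lower number from compound 3 to compound 4 (0.15 log units; within the scatter), estimated as not beyond the scatter.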

Compound 4, dissociation constant: 63.1 nM
Compound 4: middle estimate off by 1.1-fold (0.05 log units), on the high side, within the range that was stated.
By their numbers in this assay, from the lowest: compound 2; then compound 1; then compounds 4 and 3 (each within the scatter of the next).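

In this assay, with the dimethylamide held constant, isopropyl in place of trifluoromethoxy gives a 1.6-fold lower number from compound 3 to compound 4 (0.20 log units; within the scatter), so this position shows no difference beyond the scatter for this exchange. The two groups differ in heavy atoms and hydrogen-bond acceptors, yet the values do not separate them. Nothing available bears on why these two groups read alike.

As far as these compounds go, a carboxylic acid or an amine on this aromatic carbon remains open. Also open, from the compounds shown here alone, is whether the methoxy group of compounds 1 and 2 would read alike when paired with the dimethylamide.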